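The source may report more compounds than this note shows. Statements on the series, on what has been measured and on what is new or still open speak of the compounds shown alone.

Measured compounds in an ADME assay on PANC-1 cells (Homo sapiens) for cytotoxicity, read by MTT assay, with a stated time of 48 h; on this read-out lower numbers stand for stronger inhibition of growth and higher numbers for weaker inhibition of growth:
compound 1, `O=C(/C=C\c1ccccc1O)N1N=C(c2ccncc2)OC1c1c[nH]c2ccccc12` — > 30 ug/mL (a limit of the assay)
compound 2, `O=C(/C=C\c1ccccc1F)N1N=C(c2ccncc2)OC1c1c[nH]c2ccccc12` — > 30 ug/mL (a limit of the assay)

Compound 1 gives only the limit > 30 ug/mL in this assay, not a number. Compound 2 likewise gives only the limit > 30 ug/mL. Both values sit on (the limit of > 30 ug/mL in this assay, at which 2 of the 2 values shown sit), so the step that the two limits leave unreadable from compound 1 to compound 2 cannot be sized; compound 2 therefore stands only as a limit, with no readable distance to compound 1.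

Compound 3 is `O=C(/C=C\c1cccc(Cl)c1Cl)N1N=C(c2ccncc2)OC1c1c[nH]c2ccccc12`. It differs from compound 2 by 2,3-dichlorophenyl in place of 2-fluorophenyl on a double-bonded chain carbon bound to a double-bonded chain carbon. Going by the values given here, the only measured step bearing on this change, a step that the two limits leave unreadable from compound 1 to compound 2, yields no size and no direction, so no step beyond the scatter can be expected from it in this assay. Compound 3 is therefore expected to remain near the limit, estimated at 40 ug/mL with a range of 12 ug/mL to 120 ug/mL. The expected step that the limit leaves unreadable from compound 2 to compound 3 is thus small and may itself be unreadable.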

Compound 3, concentration for 50% growth inhibition: > 30 ug/mL
Compound 3: no number, only a limit; the forecaster's own chance of this, stated with the estimate: 70%; the middle value is on the limit's open side.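

No step among compound 1, compound 2 and compound 3 can be read in this assay, as each gives only a limit and not a number: the limit of > 30 ug/mL in this assay, at which 3 of the 3 values shown sit.

The compounds shown leave open how strongly any of the three inhibits growth, and whether 2-hydroxyphenyl, 2-fluorophenyl and 2,3-dichlorophenyl differ at all in this respect.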